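From 3-chlorophenyl to 2-chlorophenyl on a thiourea nitrogen

A few compounds are considered here, and "the series" means these few. Any claim that something is new, unique, unknown or untested is made for them only; others in the source may bear on it.

Of the compounds shown here, three sharing one core have been measured in a functional assay on U-373MG ATCC cells (Homo sapiens) for inhibition, read by MTT assay, with a stated time of 72 h; a lower number here means a stronger inhibitor, a higher number a weaker inhibitor. Compound 1 `CC1(C)CC(NC(=S)Nc2cccc(Cl)c2)c2cc(Br)ccc2O1` gives 8000 nM, the second highest of the three numbers. Compound 3 `CC1(C)CC(NC(=S)Nc2cccc([N+](=O)[O-])c2)c2cc(Br)ccc2O1`, which carries a nitro in place of chloro on an aromatic carbon, gives 4000 nM; the change a 2.0-fold lower number from compound 1 to compound 3 (0.30 log units; within the scatter) lies within the scatter. Within the data shown here, compound 2 `CC1(C)CC(NC(=O)Nc2ccccc2Cl)c2cc(F)ccc2O1` gives 40000 nM, a higher number than compound 1, but it differs from the others in several places at once, so it offers no single step.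

Compound 4 `CC1(C)CC(NC(=S)Nc2ccccc2Cl)c2cc(Br)ccc2O1` keeps everything of compound 1 except the change (2-chlorophenyl in place of 3-chlorophenyl on an amide-type nitrogen). Among the measured compounds shown here, no measured step tests this particular change. For the measured compounds named here, the only single step seen, from compound 1 to compound 3, stayed within the scatter, and nothing here shows a swap of this kind moving the number far. The step of a 1.5-fold higher number from compound 1 to compound 4 (0.18 log units; within the scatter) is therefore expected to stay small. Compound 4 is estimated at 12000 nM, within a range of 4000 nM to 40000 nM.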

Compound 4, half-maximal inhibitory concentration: 34000 nM
Compound 4: middle estimate off by 2.8-fold (0.45 log units), on the low side; the measured number falls inside the stated range.
By their numbers in this assay, from the lowest: compounds 3 and 1 (each within the scatter of the next); then compounds 4 and 2 (each within the scatter of the next).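

In this assay, among these compounds, 2-chlorophenyl in place of 3-chlorophenyl gives a 4.3-fold higher number from compound 1 to compound 4 (0.63 log units; beyond the scatter), the first single change in this set to lie beyond the scatter. The earlier step, a 2.0-fold lower number from compound 1 to compound 3 (0.30 log units; within the scatter), stayed within it and could suggest that this position tolerates change, but this result shows that the group on the amide-type nitrogen can matter even when the atoms stay the same and only their joining differs. Nothing available explains why the number moves.

On these data alone, it remains open whether an amine or a methoxy group in place of the chloro would keep the number close to those of compounds 1 and 3 or raise it as in compound 4. Whether this step would carry over to a urea like compound 2 is also unknown.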